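Swapping nitro for hydroxy on a methoxy-bearing ring

This account rests on a few compounds, and the source may have more. Where it says the series, first, only, none or still open, it means among the compounds named here.

Compound 1 `COc1ccc(N(C)c2cc(C)nc(C)n2)cc1` in a functional assay on HCT-116 cells (Homo sapiens) for antiproliferative activity, read by MTT assay, with a stated time of 48 h (a higher number here means a weaker inhibitor, a lower number a stronger inhibitor), gives 1320 nM
Compound 2 `COc1ccc(N(C)c2cc(C)nc(C)n2)cc1[N+](=O)[O-]` in this assay gives 4670 nM

Compound 2 holds the higher of these two numbers, which marks it as the weaker inhibitor of the pair. Compound 3 `COc1ccc(N(C)c2cc(C)nc(C)n2)cc1O` differs from compound 2 by hydroxy in place of nitro on an aromatic carbon, ortho to a methoxy group (hydroxy in place of nitro on an aromatic carbon). Going by the values given here, only one measured step bears on this change: nitro in place of hydrogen on that same carbon gave a 3.5-fold higher number from compound 1 to compound 2 (0.55 log units; beyond the scatter) in a modest move beyond the scatter. Among the compounds with values here, no compound with hydroxy has been measured, so this guide is thin. Taking nitro away may undo much of that step, so a somewhat smaller move towards a lower number is expected in this assay here. This reasoning points to an estimated 2.5-fold lower number from compound 2 to compound 3 (0.39 log units; beyond the scatter) as the likely outcome. Compound 3 is estimated at 1900 nM with a range from 550 nM to 6500 nM expected.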

Compound 3, half-maximal inhibitory concentration: 126 nM
Beside the measured number, compound 3's estimate is 15-fold (1.18 log units) above it, outside the stated range (below it).
By their numbers in this assay, from the lowest: compound 3; then compound 1; then compound 2.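

The earlier pair showed only that nitro on this aromatic carbon, ortho to a methoxy group, raised the number, whereas this result shows that the same carbon can also push the number far down in this assay and that the group placed there matters greatly. Replacing nitro with hydroxy gives a 37-fold lower number from compound 2 to compound 3 (1.57 log units; beyond the scatter) and replacing hydrogen with hydroxy gives a 10-fold lower number from compound 1 to compound 3 (1.02 log units; beyond the scatter) so hydroxy does more than cancel the nitro step and places compound 3 as the strongest inhibitor of the three. No supporting data are available to explain this large difference between the groups.

The compounds shown leave open whether this gain is special to hydroxy or would also come with an amine, a fluorine atom or a second methoxy group on this carbon. They also leave open whether hydroxy would give a similar gain on another carbon of this ring.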